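Pentyl to 4-(tert-butyl)phenyl: an Expected Cytotoxicity Value

The source may hold more compounds than are shown below. What is called first, only, known or untested is meant among the compounds shown, and "the series" means these compounds.

Compound 1 `CCCc1cc(-c2cn([C@H]3C[C@H](OC(C)=O)[C@@H](COC(C)=O)O3)c(=O)[nH]c2=O)on1`: 89.1%
Compound 2 `CCCCCc1cc(-c2cn([C@H]3C[C@H](OC(C)=O)[C@@H](COC(C)=O)O3)c(=O)[nH]c2=O)on1`: 91.9%

In a functional assay on NUGC-3 cells (Homo sapiens) for cytotoxicity, read by sulforhodamine B assay, tested at 10 uM (on this read-out higher numbers stand for more inhibition at the one concentration tested (going by the name of the read-out) and lower numbers for less inhibition), compound 1 gives 89.1% and compound 2 gives 91.9%. Compound 2 stands at the top of this pair of numbers, but the step of a number 2.8 percentage points higher from compound 1 to compound 2 (within the scatter) lies within the scatter, so the two compounds are not separated. Compound 3 `CC(=O)OC[C@H]1O[C@@H](n2cc(-c3cc(-c4ccc(C(C)(C)C)cc4)no3)c(=O)[nH]c2=O)C[C@@H]1OC(C)=O` differs from compound 2 by 4-(tert-butyl)phenyl in place of pentyl on an aromatic carbon. Among the compounds with values here, the only measured step, a number 2.8 percentage points higher from compound 1 to compound 2 (within the scatter), concerns a chain extension and bears only loosely on an aryl group entering here. Since both measured numbers are high, the expected step of a number 5.9 percentage points lower from compound 2 to compound 3 (within the scatter) is small. Compound 3 is estimated at 86%, between 65% and 97%.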

Compound 3, a percentage reported as inhibition, at one concentration (the size of the read-out at that concentration, not a potency): 32.8%
The estimate for compound 3 lay 53.2 percentage points above the measured number; the whole stated range lies above it.
By their numbers in this assay, from the lowest: compound 3; then compounds 1 and 2 (each within the scatter of the next).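

In this assay, the group on the aromatic carbon next to the ring nitrogen turns out to matter a great deal: 4-(tert-butyl)phenyl in place of pentyl gives a number 59.1 percentage points lower from compound 2 to compound 3 (beyond the scatter), and in place of propyl it gives a number 56.3 percentage points lower from compound 1 to compound 3 (beyond the scatter). The two chains alone could not show this, as their numbers were not separated. Nothing at hand explains the fall. The compounds shown leave open whether it goes with the phenyl ring or with its tert-butyl group; a plain phenyl on this carbon would separate the two. Also open, as far as these compounds go, is how a longer chain, such as octyl, would read.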